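A few compounds are considered here, and "the series" means these few. Any claim that something is new, unique, unknown or untested is made for them only; others in the source may bear on it.

Measured so far in an assay on isolated protein for inhibition of Amine oxidase [flavin-containing] A (Homo sapiens), read by fluorescence; a higher number here means a weaker inhibitor, a lower number a stronger inhibitor:
compound 1 `COc1cccc(-c2csc(NN=C(C)C)n2)c1` — 4430 nM
compound 2 `CCCCCC/C(C)=N/Nc1nc(-c2cccc(OC)c2)cs1` — 1380 nM

Compound 1 gives the highest number of the two; its nearest neighbour is compound 2, and the step from compound 1 to compound 2 is a 3.2-fold lower number from compound 1 to compound 2 (0.51 log units; beyond the scatter) in this assay, the change being pentyl in place of hydrogen on a saturated chain carbon bound to a carbon with a double bond to nitrogen.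

Compound 3 `COc1cccc(-c2csc(N/N=C/c3cccs3)n2)c1` is not yet measured. It differs from compound 1 by a group of 7 heavy atoms (5 carbon, 1 nitrogen, 1 sulfur; one five-membered aromatic ring with 1 hetero atom) in place of a group of 4 heavy atoms (3 carbon, 1 nitrogen; no ring), on a nitrogen on an aromatic ring.

Among the compounds with values here, only one measured step bears on this part of the structure, that from compound 1 to compound 2, and it is modest. It shows that enlarging the group on this nitrogen lowered the number; the group entering in compound 3 is likewise larger than what leaves, though of a different kind, so the direction is taken from compound 2 with low confidence. A step of about a 3.0-fold lower number from compound 1 to compound 3 (0.47 log units; beyond the scatter) is expected. Compound 3 is therefore estimated at 1500 nM in this assay, within 400 nM to 5500 nM.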

Compound 3, half-maximal inhibitory concentration: 458 nM
Compound 3: middle estimate off by 3.3-fold (0.52 log units), on the high side; measured number inside the range.
By their numbers in this assay, from the lowest: compound 3; then compound 2; then compound 1.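

In this assay, replacing the group of 4 heavy atoms on a nitrogen on an aromatic ring with a group carrying a five-membered aromatic ring with 1 hetero atom gives a 9.7-fold lower number from compound 1 to compound 3 (0.99 log units; beyond the scatter). Until now this position had been probed only with a saturated chain, through a 3.2-fold lower number from compound 1 to compound 2 (0.51 log units; beyond the scatter); the new result shows that it also accepts an aromatic ring, and that this ring-bearing group gives the lowest number among the three compounds. Nothing available explains why the group in compound 3 gives this result.

The compounds shown cannot separate the contribution of the aromatic ring from that of its sulfur atom, a question that a phenyl ring or a furan ring in the same place would address. They also leave open whether the series would respond similarly to a ring carrying a substituent, such as a methyl group or a chlorine atom, or to a ring held on a longer chain.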